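Adding 2,2-difluoroethoxy to compound 1: what to expect

The source may hold more compounds than are shown below. What is called first, only, known or untested is meant among the compounds shown, and "the series" means these compounds.

Measured so far in an ADME assay on liver (Homo sapiens) for metabolic stability, using microsomes (a higher number here means that the compound lasts longer, a lower number that the compound disappears faster), are two compounds:
- compound 1 `CN1Cc2cc(ccc2S(=O)(=O)C2CC2)NC(=O)CCc2cccc(c2)[C@@H](Nc2ccc3c(N)ncc(F)c3c2)C1=O` with 0.217 h as its half-life
- compound 2 `COc1cc2cc(c1)[C@@H](Nc1ccc3c(N)ncc(F)c3c1)C(=O)N(C)Cc1cc(ccc1S(=O)(=O)C1CC1)NC(=O)CC2` with 0.25 h as its half-life

Within the data shown here, compound 1 stands at 0.217 h in this assay and has only one measured neighbour. Compound 1 and compound 2 lie within the scatter of each other, so the two cannot be ranked.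

Compound 3 `CN1Cc2cc(ccc2S(=O)(=O)C2CC2)NC(=O)CCc2cc(ccc2OCC(F)F)[C@@H](Nc2ccc3c(N)ncc(F)c3c2)C1=O` has not been measured. It keeps the core of compound 1 and carries one change, 2,2-difluoroethoxy in place of hydrogen on an aromatic carbon in which the new group sits ortho to a fused ring and para to a fused ring.

Among the measured compounds shown here, the one measured step that bears on this is a 1.2-fold higher number from compound 1 to compound 2 (0.06 log units; within the scatter) for methoxy in place of hydrogen on an aromatic carbon. It is a single example with a different group, and no measurement of 2,2-difluoroethoxy exists here.

For the measured compounds named here, with that step as the only guide, no shift beyond the scatter is expected in this assay and neither direction is favoured. The expected size is a 1.2-fold higher number from compound 1 to compound 3 (0.06 log units; within the scatter) and this stays within the scatter. Compound 3 is therefore estimated at 0.25 h with an expected range from 0.12 h to 0.5 h for its half-life.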

Compound 3, half-life: 0.533 h
The estimate for compound 3 lay 2.1-fold (0.33 log units) below the measured number, outside the stated range (above it).
By their numbers in this assay, from the lowest: compounds 1 and 2 (each within the scatter of the next); then compound 3.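

In this assay, 2,2-difluoroethoxy in place of hydrogen on this aromatic carbon, ortho to a fused ring and para to a fused ring, gives a 2.5-fold higher number from compound 1 to compound 3 (0.39 log units; beyond the scatter). This is the first change in the series shown to move the half-life beyond the scatter, and it shows that this carbon of the core of compound 1 can carry the group with a modest gain, whereas the only earlier step, a 1.2-fold higher number from compound 1 to compound 2 (0.06 log units; within the scatter), allowed no such reading. Nothing measured here explains the gain seen with compound 3.

The compounds shown leave open whether the gain belongs to the fluorine atoms, to the ether oxygen or to this position itself, since only one group has been seen on this carbon, and a plain ethoxy or a methoxy there would be needed to separate these. They also leave open how the half-life would respond to other groups at this place, such as 2,2,2-trifluoroethoxy, a longer fluorinated chain or an amine.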